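This account rests on a few compounds, and the source may have more. Where it says the series, first, only, none or still open, it means among the compounds named here.

In a functional assay on NALM-6 cells (Homo sapiens) for cytotoxicity, with a stated time of 72 h (a lower number here means that less compound is needed, a higher number that more compound is needed for the effect), compound 1 (`C=C[C@](C)(CCCC(C)C)CCc1ccc(O)cc1`) gives 27500 nM. Compound 2 (`C=C[C@@](C)(/C=C/c1ccc(O)cc1)CCC(O)C(C)(C)O`) is reported only as a limit, > 43400 nM. Compound 3 (`C=C[C@@](C)(/C=C/c1ccc(O)cc1)CC/C=C(\C)C=O`) carries 2-formylprop-1-en-1-yl in place of 1,2-dihydroxy-2-methylpropyl on a saturated chain carbon, three bonds along the chain from two double-bonded chain carbons. Going by the values given here, no measured pair shows this change, and the only number to lean on is that of compound 1, 27500 nM. A moderate move towards a lower number in this assay is expected, with an estimated at least 2.4-fold lower number from compound 2 to compound 3 (0.38 log units; beyond the scatter). For compound 3 the estimated value is 18000 nM, with an expected range of 6000 nM to 43000 nM.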

Compound 3, half-maximal effective concentration: 12600 nM
Beside the measured number, compound 3's estimate is 1.4-fold (0.15 log units) above it, within the range that was stated.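

At this saturated chain carbon, three bonds along the chain from two double-bonded chain carbons, 2-formylprop-1-en-1-yl in place of 1,2-dihydroxy-2-methylpropyl gives a measured number in this assay (with an at least 3.4-fold lower number from compound 2 to compound 3 (0.53 log units; beyond the scatter)). Going by these compounds alone, this is the first reading of a change at this position, and it lies beyond the usual scatter. From the compounds shown here alone, its full size remains unknown, because compound 2 is reported only as a limit of the assay and not as a number: the limit of > 43400 nM in this assay, at which 1 of the 3 values shown sits.

Going by these compounds, whether the step follows from the formyl group or from the loss of the hydroxyl groups remains open. So does the outcome with an amine or a carboxylic acid at this position.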